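A Chloro Group Added to Compound 3

The source may report more compounds than this note shows. Statements on the series, on what has been measured and on what is new or still open speak of the compounds shown alone.

Four compounds share one core: compound 1 `CCCCCCC(CCO)n1cnc2c(N)nc(Cl)nc21`, compound 2 `CCCCCCCCC(CCO)n1cnc2c(Cl)nc(Cl)nc21`, compound 3 `CCCCCCCCC(CCO)n1cnc2c(N)ncnc21` and compound 4 `CCCCCCCCC(CCO)n1cnc2c(N)nc(Cl)nc21`. In a functional assay on SW480 cells (Homo sapiens) for antiproliferative activity, read by MTT assay, with a stated time of 48 h (a lower number here means a stronger inhibitor, a higher number a weaker inhibitor), compound 3 gives 20700 nM and compound 2 gives 24000 nM, values within the scatter of each other. Compound 1 also carries the chloro group of compound 4, and for compound 1 the reading > 50000 nM is a limit of the assay. Compound 4 has chloro in place of hydrogen on an aromatic carbon, between two ring nitrogen atoms (chloro in place of hydrogen on an aromatic carbon). For the measured compounds named here, no measured pair isolates this change, so no step beyond the scatter is expected in this assay. The expected change is a 1.0-fold lower number from compound 3 to compound 4 (0.01 log units; within the scatter). Compound 4 is estimated at 20000 nM, with an expected range of 9000 nM to 45000 nM.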

Compound 4, half-maximal inhibitory concentration: 13100 nM
Compound 4: the middle estimate sits 1.5-fold (0.18 log units) above what was measured, and the stated range covers the measured number.
By their numbers in this assay, from the lowest: compounds 4, 3 and 2 (each within the scatter of the next). At a limit, above all of these: compound 1.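

In this assay, chloro on the aromatic carbon between two ring nitrogen atoms gives a 1.6-fold lower number from compound 3 to compound 4 (0.20 log units; within the scatter), so this position takes chloro without a change beyond the scatter. Amino in place of chloro on an aromatic carbon likewise gives only a 1.8-fold lower number from compound 2 to compound 4 (0.26 log units; within the scatter). For the compounds shown here, the chain change gives an at least 3.8-fold lower number from compound 1 to compound 4 (0.58 log units; beyond the scatter), the only step here beyond the scatter, and it is read from a limit of the assay: the limit of > 50000 nM in this assay, at which 1 of the 4 values shown sits.

As far as these compounds go, whether fluoro, methyl or methoxy at this position would shift the number beyond the scatter remains open. So does the effect of a chain longer than that of compound 4.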